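Changing the Aryl Group on the Thiourea of Compound 2

This account rests on a few compounds, and the source may have more. Where it says the series, first, only, none or still open, it means among the compounds named here.

Compound 1, `CC(C)NC(=O)c1cc(Oc2cccc(NC(=S)Nc3ccc(Cl)cc3)c2)ccn1`, gives 22100 nM in a functional assay on HCT-116 cells (Homo sapiens) for cytotoxicity, read by MTT assay, with a stated time of 48 h; on this read-out higher numbers stand for weaker inhibition and lower numbers for stronger inhibition.
Compound 2, `O=C(NCc1ccccc1)c1cc(Oc2cccc(NC(=S)Nc3ccc(Cl)cc3)c2)ccn1`, gives 16500 nM.
Compound 3, `O=C(NC1CCCCC1)c1cc(Oc2cccc(NC(=S)Nc3ccc(F)c(F)c3)c2)ccn1`, gives 8900 nM.

Compound 2 stands second highest of the three numbers, and both neighbours lie within the scatter of it. Within the data shown here, the only single-place step, a 1.3-fold lower number from compound 1 to compound 2 (0.13 log units; within the scatter), concerns the amide substituent, not the aryl group on the thiourea. Compound 4, `O=C(NCc1ccccc1)c1cc(Oc2cccc(NC(=S)Nc3cccc(C(F)(F)F)c3)c2)ccn1`, differs from compound 2 by 3-(trifluoromethyl)phenyl in place of 4-chlorophenyl on an amide-type nitrogen. Among the measured compounds shown here, no measured step bears on this change; compound 3 carries a different aryl group but also a different amide substituent, so its value shows only that such a variant lands near the others. A step of no size beyond the scatter is therefore expected, a 1.2-fold lower number from compound 2 to compound 4 (0.07 log units; within the scatter). Compound 4 is estimated at 14000 nM, within 5000 nM to 40000 nM.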

Compound 4, half-maximal inhibitory concentration: 7500 nM
The estimate for compound 4 lay 1.9-fold (0.27 log units) above the measured number; low and high end bracket the measured number.
By their numbers in this assay, from the lowest: compounds 4, 3, 2 and 1 (each within the scatter of the next, the first and the last beyond it).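

With the benzyl amide held constant, a 2.2-fold lower number from compound 2 to compound 4 (0.34 log units; beyond the scatter) shows that in this assay replacing 4-chlorophenyl with 3-(trifluoromethyl)phenyl on the thiourea nitrogen moves the number beyond the scatter, though only modestly. Among these compounds, the one earlier single-place step, a 1.3-fold lower number from compound 1 to compound 2 (0.13 log units; within the scatter), changed the amide substituent and stayed within the scatter. No measurement at hand accounts for the new step.

On these data alone, whether a methoxy or nitrile group on this aryl ring, or a hexyl chain in its place, would give a lower number remains open. So does whether the step carries over to the isopropyl amide of compound 1.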